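N-methylation of compound 2: expected effect on potency

This account rests on a few compounds, and the source may have more. Where it says the series, first, only, none or still open, it means among the compounds named here.

Measured in a functional assay on HCT-116 cells (Homo sapiens) for antiproliferative activity, read by MTT assay, with a stated time of 48 h; a lower number here means a stronger inhibitor, a higher number a weaker inhibitor:
- compound 1 `CCCCCCC(CCO)n1cnc2c(N(C)C)ncnc21` | > 50000 nM (a limit)
- compound 2 `CCCCCCCCC(CCO)n1cnc2c(NC)ncnc21` | 3730 nM

In this assay, among the compounds with values here, compound 2 holds the only actual number of the pair (3730 nM). Compound 1 gives only a limit (> 50000 nM).

Compound 3 `CCCCCCCCC(CCO)n1cnc2c(N(C)C)ncnc21` departs from compound 2 by a single change (methyl in place of hydrogen on a nitrogen on an aromatic ring), with methyl in place of hydrogen on a nitrogen on an aromatic ring, so methylamino becomes dimethylamino. Within the data shown here, no measured step isolates this change, so its size remains a judgement. A moderate loss of potency is expected, meaning a higher number in this assay. The expectation leans that way on compound 1, which also carries dimethylamino and whose value is a limit (> 50000 nM). The expected step is a 2.1-fold higher number from compound 2 to compound 3 (0.33 log units; beyond the scatter). Compound 3 is estimated at 8000 nM, with an expected range of 2500 nM to 35000 nM.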

Compound 3, half-maximal inhibitory concentration: 19800 nM
Compound 3: the middle estimate sits 2.5-fold (0.39 log units) below what was measured; the measured number falls inside the stated range.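

In this assay, a second methyl on the nitrogen on the aromatic ring lowers potency when taken alone, giving a 5.3-fold higher number from compound 2 to compound 3 (0.72 log units; beyond the scatter), so the change from methylamino to dimethylamino now has a measured size in this series. With dimethylamino held fixed, the chain matters as well: ethyl in place of hydrogen on a saturated chain carbon, seven bonds along the chain from an aromatic nitrogen, gives an at least 2.5-fold lower number from compound 1 to compound 3 (0.40 log units; beyond the scatter). That second step is a bound rather than a size, as compound 1 stands only as a limit: the limit of > 50000 nM in this assay, at which 1 of the 3 values shown sits.

The compounds shown leave open whether potency falls further with an ethylamino or cyclopropylamino group on this nitrogen, or improves with the unsubstituted amine. Also open, as far as these compounds go, is whether a longer chain would lower the number further.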